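This account rests on a few compounds, and the source may have more. Where it says the series, first, only, none or still open, it means among the compounds named here.

Measured so far in an ADME assay on microsomes from liver (Mus musculus) for metabolic stability, with a stated time of 10 min, tested at 0.5 uM; on this read-out lower numbers stand for a less stable compound and higher numbers for a more stable compound:
Compound 1 `CC(C)COc1ncc(-c2cn(C)c3cc(C(=O)NS(=O)(=O)C4CC4)c(F)cc23)cc1Cl` gives 100%
Compound 2 `CC(C)COc1ncc(-c2nn(C)c3cc(C(=O)NS(C)(=O)=O)ccc23)cc1Cl` gives 100%
Compound 3 `Cn1cc(-c2ccc(C(F)(F)F)cc2)c2ccc(C(=O)NS(C)(=O)=O)cc21` gives 54%

Compound 1 stands level with compound 2, and together they hold the highest of the three numbers. Compound 3 lies well below them, a gap beyond the usual scatter. The next compound to be read is compound 4 `CC(C)COc1ccc(-c2cn(C)c3cc(C(=O)NS(=O)(=O)C4CC4)c(F)cc23)cn1`, which differs from compound 1 in one place: hydrogen in place of chloro on an aromatic carbon. In short, it carries hydrogen in place of chloro on an aromatic carbon.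

Among the compounds with values here, no pair of measured compounds differs in one place, so the data give no direct size for this change. Compound 1, at 100%, has no room to rise on this read-out, so any real movement can only be downward. Compound 3, at 54%, shows that a lower reading occurs in this small set, but it differs from compound 1 in more than one place and sets no size for this change. The expected result is a number 15 percentage points lower from compound 1 to compound 4 (beyond the scatter), a modest fall that may not clear the scatter by much. For compound 4 the estimated value in this assay is 85%, with an expected range from 62% to 100% as the likely span.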

Compound 4, percent of the compound remaining: 98%
The estimate for compound 4 lay 13 percentage points below the measured number, within the range that was stated.
By their numbers in this assay, from the lowest: compound 3; then compounds 4, 1 and 2 (each within the scatter of the next).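

In this assay, the one-place step reads a number 2 percentage points lower from compound 1 to compound 4 (within the scatter), which gives the set its first direct size for hydrogen in place of chloro on an aromatic carbon. At this place, ortho to an isobutoxy group and two atoms from the ring nitrogen, the chloro can therefore leave this core without a change that stands out from the scatter, and the pair stays at the top of the scale. That top position also limits the reading, since the pair shows only that no clear loss appears within the stated time and cannot separate the two compounds any further. Nothing available here explains why the reading holds with or without the chloro.

Still open, as far as these compounds go, is how other groups at this same place would read, for example fluoro, methyl, nitrile or an amine, and whether any of them would bring the number down from the top of the scale. Also open, from the compounds shown here alone, is whether the same swap would read the same way with a shorter chain, such as methoxy, in place of the isobutoxy group.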